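The source may hold more compounds than are shown below. What is called first, only, known or untested is meant among the compounds shown, and "the series" means these compounds.

In an assay on isolated protein (blood) for antagonist activity at C-C chemokine receptor type 4 (Homo sapiens), read by flow cytometry, with a stated time of 30 min (a lower number here means tighter binding, a higher number weaker binding), compound 3 `COc1cccc2c1c(NS(=O)(=O)c1ccc(Cl)s1)nn2Cc1cccc(CNC(=O)C2CCCO2)c1` gives 794 nM. Compound 1 `CC(=O)NCc1cccc(Cn2nc(NS(=O)(=O)c3ccc(Cl)s3)c3c(O)cccc32)c1` gives 794 nM, so compound 3 and compound 1 stand level at the digits shown and together have the lowest numbers of the three measured compounds. Among the measured compounds shown here, compound 2 `CC(=O)NCc1cccc(Cn2nc(NS(=O)(=O)c3ccc(Cl)s3)c3c(C(F)F)cccc32)c1` gives 7940 nM, the highest number; the single step measured here, a 10-fold higher number from compound 1 to compound 2 (1.00 log units; beyond the scatter), comes from swapping a hydroxy for a difluoromethyl on the shared core, and it lies beyond the scatter.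

Compound 4 `COc1cccc2c1c(NS(=O)(=O)c1ccc(Cl)s1)nn2Cc1cccc(CNC(=O)[C@@H]2CCCCN2)c1` differs from compound 3 at the other end of the molecule: piperidin-2-yl in place of oxolan-2-yl on a carbonyl carbon. For the measured compounds named here, that change leaves the shared core untouched, so the one measured step, which alters only the core, does not speak directly to it. Going by the values given here, no measured pair shows what exchanging the ring on that carbonyl carbon does in this assay, and the two compounds that share the methoxy core with compound 4, compound 3 and compound 1 by its own hydroxy analogue, give no guidance on the amide side either.

Among the compounds with values here, with no direct precedent, the step of a 1.1-fold lower number from compound 3 to compound 4 (0.05 log units; within the scatter) is expected to stay within the usual scatter. Compound 4 is therefore estimated to give 700 nM in this assay, within a range from 200 nM to 2500 nM.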

Compound 4, dissociation constant in the C-C chemokine receptor type 4 assay: 126 nM
Beside the measured number, compound 4's estimate is 5.6-fold (0.74 log units) above it; measured number below the stated range.
By their numbers in the C-C chemokine receptor type 4 assay, from the lowest: compound 4; then compounds 1 and 3 (each within the scatter of the next); then compound 2.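

In the C-C chemokine receptor type 4 assay, the group on the carbonyl carbon proves able to shift binding: a 6.3-fold lower number from compound 3 to compound 4 (0.80 log units; beyond the scatter), and compound 4 gives 126 nM with piperidin-2-yl in place of oxolan-2-yl. Among the compounds shown here, the only earlier step changed a group on the shared core, so this is the first measured sign that the other end of the molecule also matters, and here the number falls rather than rises. The exchange alters several things at once, as the five-membered ring becomes a six-membered ring, its oxygen gives way to nitrogen, a hydrogen-bond donor enters and a defined stereocentre appears, and nothing available says which of these accounts for the step.

The compounds shown leave open whether the lower number would survive with the opposite stereocentre, with pyrrolidin-2-yl as a smaller nitrogen ring, or with an open-chain amine such as aminomethyl on the carbonyl carbon, and whether piperidin-2-yl would act the same way on the hydroxy core of compound 1. In a physicochemical assay for acid dissociation, compound 3 is entered as "not determined" (no result reported) and compound 4 as "not determined" (no result reported) with no result reported, so no step can be read there.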